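Swapping Bromo for Methylamino on a Urea Series

The source may report more compounds than this note shows. Statements on the series, on what has been measured and on what is new or still open speak of the compounds shown alone.

Compound 1 `O=C(Nc1ccc(-n2ncc3c(C(F)(F)F)cccc32)cc1)Nc1ccc(Cl)c(C(F)(F)F)c1`: in a functional assay on OS-RC-2 cells (Homo sapiens) for cytotoxicity, read by MTT assay, with a stated time of 72 h (a lower number here means a stronger inhibitor, a higher number a weaker inhibitor), compound 1 gives > 32000 nM, which is a limit of the assay and not a number.
Compound 2 `O=C(Nc1ccc(-n2ncc3c(Br)cccc32)cc1)Nc1ccc(Cl)c(C(F)(F)F)c1`: in this assay compound 2 gives 9900 nM.
Compound 3 `O=C(Nc1ccc(-n2ncc3ccccc32)cc1)Nc1ccc(Cl)c(C(F)(F)F)c1`: in this assay compound 3 gives 32000 nM.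

Among the numbers shown, compound 2 has the lowest; its nearest neighbour is compound 3, reached by a 3.2-fold higher number from compound 2 to compound 3 (0.51 log units; beyond the scatter). Compound 4 `CNc1cccc2c1cnn2-c1ccc(NC(=O)Nc2ccc(Cl)c(C(F)(F)F)c2)cc1` has not been measured. It differs from compound 2 in one place: methylamino in place of bromo on an aromatic carbon.

Two measured steps change the group on that same carbon. Hydrogen in place of bromo brought a 3.2-fold higher number from compound 2 to compound 3 (0.51 log units; beyond the scatter), a modest loss. Bromo in place of trifluoromethyl brought an at least 3.2-fold lower number from compound 1 to compound 2 (0.50 log units; beyond the scatter), whose size is left open by the limit for compound 1. Both steps are modest, and neither tests methylamino, so a shift of similar size in either direction is plausible, with a loss slightly more common.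

Compound 4 is therefore expected to give about 16000 nM in this assay, estimated between 4000 nM and 50000 nM. This estimate means a 1.6-fold higher number from compound 2 to compound 4 (0.21 log units; within the scatter), expected to be a modest weakening.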

Compound 4, half-maximal inhibitory concentration: 10600 nM
Beside the measured number, compound 4's estimate is 1.5-fold (0.18 log units) above it; measured number inside the range.
By their numbers in this assay, from the lowest: compounds 2 and 4 (each within the scatter of the next); then compound 3.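

In this assay, methylamino in place of bromo gives a 1.1-fold higher number from compound 2 to compound 4 (0.03 log units; within the scatter), so this position accepts both groups with no readable difference, although they share no atom and only methylamino carries a hydrogen-bond donor. For the compounds shown here, measured against hydrogen on the same aromatic carbon, methylamino gives a 3.0-fold lower number from compound 3 to compound 4 (0.48 log units; beyond the scatter), which shows that bromo is not the only group here to give a lower number than hydrogen. Replacing trifluoromethyl with methylamino gives an at least 3.0-fold lower number from compound 1 to compound 4 (0.47 log units; beyond the scatter), but this step is only a bound, and its true size stays unknown: the limit of > 32000 nM in this assay, at which 1 of the 4 values shown sits.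

The compounds shown leave open whether any other group on this carbon, such as a dimethylamino group, a methoxy group or a carboxylic acid, would take the number clearly below those of bromo and methylamino. They also leave open whether the match between bromo and methylamino holds when the rest of the molecule changes.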